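Linker homologation from compound 2 to compound 3

This account rests on a few compounds, and the source may have more. Where it says the series, first, only, none or still open, it means among the compounds named here.

Measured so far:
Compound 1, `CC(C)NC(=N)c1ccc2oc(-c3ccc(OCCCCCOc4ccccc4)cc3)cc2c1`, gives 20500 nM in an ADME assay on L6 cells (Rattus norvegicus) for cytotoxicity, read by resazurin assay, with a stated time of 70 h; a lower number here means a stronger inhibitor, a higher number a weaker inhibitor.
Compound 2, `c1ccc(OCCCCCOc2ccc(-c3cc4cc(C5=NCCN5)ccc4o3)cc2)cc1`, gives 900 nM in this assay.

Compound 2 stands at the lowest of the two numbers. Among the measured compounds shown here, its nearest neighbour is compound 1, and the single step in hand, a 23-fold lower number from compound 1 to compound 2 (1.36 log units; beyond the scatter), comes from exchanging the group on the aromatic carbon of the shared core; the five-membered ring with two hetero atoms sits on the compound with the lower number.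

Compound 3, `c1ccc(OCCCCCCOc2ccc(-c3cc4cc(C5=NCCN5)ccc4o3)cc2)cc1`, keeps that ring and differs from compound 2 only in the linker: phenoxymethyl in place of phenoxy on a saturated chain carbon, five bonds along the chain from an oxygen on an aromatic ring. For the measured compounds named here, no measured step touches the chain, so the one step in hand, a 23-fold lower number from compound 1 to compound 2 (1.36 log units; beyond the scatter), bears on a different part of the molecule and gives no direct guide to the size or direction of this change. With nothing to point either way, a step within the scatter is expected: no change at the digits printed from compound 2 to compound 3 (within the scatter).

For compound 3 the estimate in this assay is 900 nM, with a range of 350 nM to 2500 nM.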

Compound 3, half-maximal inhibitory concentration: 1500 nM
Beside the measured number, compound 3's estimate is 1.7-fold (0.22 log units) below it; measured number inside the range.
By their numbers in this assay, from the lowest: compounds 2 and 3 (each within the scatter of the next); then compound 1.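

In this assay, among the compounds shown here, the step of a 1.7-fold higher number from compound 2 to compound 3 (0.22 log units; within the scatter) is the first reading on the linker, and it shows that phenoxymethyl can stand in place of phenoxy, on a saturated chain carbon, five bonds along the chain from an oxygen on an aromatic ring, without the number leaving the scatter. For the compounds shown here, the only earlier step, a 23-fold lower number from compound 1 to compound 2 (1.36 log units; beyond the scatter), came from the group on the aromatic carbon of the shared core and said nothing about the chain. With the five-membered ring held constant, this change at the chain gives no measurable separation between compound 2 and compound 3, and no evidence bearing on this result is available.

A single step cannot show whether the same holds further along the series, for example for 2-phenoxyethyl, 3-phenoxypropyl, 4-phenoxybutyl or a still longer chain in place of phenoxymethyl at this place. Also open, as far as these compounds go, is how the number in this assay would respond to an amine or a carboxylic acid in place of the terminal phenoxy group, since both compounds with the five-membered ring keep that aromatic end unchanged.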